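A few compounds are considered here, and "the series" means these few. Any claim that something is new, unique, unknown or untested is made for them only; others in the source may bear on it.

Measured compounds:
- compound 1, `CN(C)C(=O)c1cccnc1NCCCN1CCN(c2ccccc2C#N)CC1`, 10 nM in a functional assay on aorta for antagonist activity at Alpha-1D adrenergic receptor (Rattus norvegicus); on this read-out lower numbers stand for tighter binding and higher numbers for weaker binding
- compound 2, `CN(C)C(=O)c1cccnc1NCCCN1CCN(c2ccccc2OCC(F)(F)F)CC1`, 15.9 nM in this assay
- compound 3, `CSc1ccccc1N1CCN(CCCNc2ncccc2C(=O)N(C)C)CC1`, 31.6 nM in this assay

Among these three numbers compound 3 holds the highest. Its nearest neighbour is compound 2, and that gap, a 2.0-fold higher number from compound 2 to compound 3 (0.30 log units; within the scatter), is within the scatter; the gap to compound 1, a 3.2-fold higher number from compound 1 to compound 3 (0.50 log units; beyond the scatter), lies beyond it. Compound 4, `COc1ccc(N2CCN(CCCNc3ncccc3C(=O)N(C)C)CC2)c(OC)c1`, has not been measured. It differs from compound 3 by 2,4-dimethoxyphenyl in place of 2-(methylsulfanyl)phenyl on an amine nitrogen in a ring. All three measured steps exchange the group on that same phenyl ring: a 1.6-fold higher number from compound 1 to compound 2 (0.20 log units; within the scatter) and a 2.0-fold higher number from compound 2 to compound 3 (0.30 log units; within the scatter) stayed within the scatter, and a 3.2-fold higher number from compound 1 to compound 3 (0.50 log units; beyond the scatter) was modest. For the measured compounds named here, no measured step puts a dimethoxyphenyl in place of any of these groups, so the size of this change rests on the spread seen so far, which is narrow. The account therefore expects at most a small move in this assay, in either direction, and most likely none beyond the scatter. The expected step is a 1.3-fold lower number from compound 3 to compound 4 (0.10 log units; within the scatter). Compound 4 is estimated at 25 nM, with a range from 8 nM to 80 nM.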

Compound 4, dissociation constant: 1000 nM
Estimate against measurement, compound 4: 40-fold (1.60 log units) below, and the stated range ends below it.
By their numbers in this assay, from the lowest: compounds 1, 2 and 3 (each within the scatter of the next, the first and the last beyond it); then compound 4.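

In this assay, for the compounds shown here, the group on this amine nitrogen in a ring proves far less tolerant of exchange than the earlier compounds suggested, with a 32-fold higher number from compound 3 to compound 4 (1.50 log units; beyond the scatter) standing well outside the narrow spread of the earlier steps. The same exchange position also gives a 100-fold higher number from compound 1 to compound 4 (2.00 log units; beyond the scatter) as a step, so 2,4-dimethoxyphenyl separates clearly from both 2-(methylsulfanyl)phenyl and 2-cyanophenyl on an otherwise unchanged core. Nothing shown here accounts for this large rise in the number.

The compounds shown leave open whether the rise goes with both methoxy groups together or with only one of them. A phenyl ring bearing a single methoxy group would be the comparison that could separate these two readings.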